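Amide ring swap on the aryl group of compound 3

This account rests on a few compounds, and the source may have more. Where it says the series, first, only, none or still open, it means among the compounds named here.

Measured so far in an assay on membranes from brain (strain Sprague-Dawley) for displacement of a labelled ligand from adenosine receptor A1 (Rattus norvegicus), read by scintillation counting, with a stated time of 1 h; a higher number here means a weaker inhibitor, a lower number a stronger inhibitor:
compound 1 `Cc1ccc(-c2cc(-c3cccc(Cl)c3)nc(N)n2)o1`: 129 nM
compound 2 `COc1cccc(-c2cc(-c3ccc(C)o3)nc(N)n2)c1`: 145 nM
compound 3 `Cc1ccc(-c2cc(-c3cccc(C(=O)N4CCOCC4)c3)nc(N)n2)o1`: 52.1 nM

Compound 3 gives the lowest number of the three in this assay; the gaps to compound 1 and to compound 2 both lie beyond the scatter, so it is the strongest inhibitor shown. The two steps that lead to it, a 2.5-fold lower number from compound 1 to compound 3 (0.39 log units; beyond the scatter) and a 2.8-fold lower number from compound 2 to compound 3 (0.44 log units; beyond the scatter), are modest; a 1.1-fold higher number from compound 1 to compound 2 (0.05 log units; within the scatter) is within the scatter.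

Compound 4 `Cc1ccc(-c2cc(-c3cccc(C(=O)N4CCCCC4)c3)nc(N)n2)o1` differs from compound 3 by piperidin-1-yl in place of morpholin-4-yl on a carbonyl carbon. Going by the values given here, no measured step changes the ring of the amide, so none bears on it directly; the steps to compound 3 only show that the amide as a whole is worth a modest gain over chloro or methoxy. With nothing to suggest a shift in either direction, the expected step in this assay is none beyond the scatter, a 1.1-fold higher number from compound 3 to compound 4 (0.02 log units; within the scatter). Compound 4 is therefore estimated at 55 nM, with a range from 20 nM to 150 nM.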

Compound 4, inhibition constant: 9.54 nM
Estimate against measurement, compound 4: 5.8-fold (0.76 log units) above; the measured number lies below the stated range.
By their numbers in this assay, from the lowest: compound 4; then compound 3; then compounds 1 and 2 (each within the scatter of the next).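

In this assay the ring of the amide turns out to matter: piperidin-1-yl in place of morpholin-4-yl on the carbonyl carbon gives a 5.5-fold lower number from compound 3 to compound 4 (0.74 log units; beyond the scatter), so the gain of the amide over the simple groups varies with the ring it carries. Against those groups, (piperidin-1-yl)carbonyl gives a 14-fold lower number from compound 1 to compound 4 (1.13 log units; beyond the scatter) and a 15-fold lower number from compound 2 to compound 4 (1.18 log units; beyond the scatter), both large where the steps to compound 3 were modest, and compound 4 is the strongest inhibitor of the four. Nothing available explains the gap between the two rings.

Going by these compounds, whether the step follows the ring oxygen or some other difference between the two rings stays open. A pyrrolidine amide, a piperazine amide or an open-chain diethylamide on the same carbonyl would test how far the trend extends.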